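Moving the chlorine on the benzyl group of compound 3

A few compounds are considered here, and "the series" means these few. Any claim that something is new, unique, unknown or untested is made for them only; others in the source may bear on it.

Of the compounds shown here, three have so far been measured in a functional assay on HEL cells (Homo sapiens) for inhibition; a lower number here means that less compound is tolerated, a higher number that more compound is tolerated. Compound 1 `O=C1c2ccccc2N(Cc2ccccc2)S(=O)(=O)N1COCc1ccccc1` gives > 98000 nM in this assay, which is a limit of the assay and not a number. Compound 2 `O=S1(=O)N=C(OCc2ccccc2)c2ccccc2N1Cc1ccccc1` gives > 200000 nM in this assay, again a limit. Compound 3 `O=C1c2ccccc2N(Cc2ccc(Cl)cc2)S(=O)(=O)N1Cc1ccccc1` gives > 200000 nM in this assay, also a limit. Compound 3 thus sits at the limit of > 200000 nM in this assay, at which 2 of the 3 values shown sit, whereas compound 1 sits at the limit of > 98000 nM in this assay, at which 1 of the 3 values shown sits. Within the data shown here, since every value in this set is a limit, no pair of compounds that differ in a single place offers a measured step, and nothing ranks compound 3 against the other two.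

Compound 4 `O=C1c2ccccc2N(Cc2cccc(Cl)c2)S(=O)(=O)N1Cc1ccccc1` differs from compound 3 in one place: 3-chlorophenyl in place of 4-chlorophenyl on a saturated chain carbon bound to a sulfonamide nitrogen in a ring The two structures hold the same atoms, joined differently, and the shared core of compound 3 is otherwise untouched. Among the measured compounds shown here, with every measured value a limit and no measured step to lean on, the account expects no step beyond the scatter in either direction; the expected step is a step that the limit leaves unreadable from compound 3 to compound 4. Compound 4 is accordingly estimated at 250000 nM in this assay, with a range from 120000 nM to 700000 nM, and it is expected most likely to be reported only as a limit.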

Compound 4, half-maximal cytotoxic concentration: > 200000 nM
Compound 4 was reported as a limit; the forecaster's own chance of this, stated with the estimate: 85%; the middle value lies beyond the limit too.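

Among these compounds, compound 3 and compound 4 are both reported only as limits in this assay, so no step between them can be read. The compounds shown leave open whether 4-chlorobenzyl and 3-chlorobenzyl differ at all in this assay, and at what concentration, if any, a compound of this set reaches a half-maximal cytotoxic effect.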